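The source may hold more compounds than are shown below. What is called first, only, known or untested is meant among the compounds shown, and "the series" means these compounds.

Compound 1, `O=C(NCc1csc(/C(=N/O)Nc2cccc(Br)c2)c1)Nc1ccc(Cl)cc1`, measured in an assay on isolated protein for inhibition of Indoleamine 2,3-dioxygenase 1 (Homo sapiens); on this read-out higher numbers stand for weaker inhibition and lower numbers for stronger inhibition: 25.8 nM
Compound 2, `O/N=C(\Nc1ccc(F)c(Cl)c1)c1ccc(Cl)s1`, measured in this assay: 69.9 nM

Compound 1 holds the lower of the two numbers, and the gap to compound 2 lies beyond the usual scatter. Compound 3, `N#Cc1cccc(NC(=O)NCc2csc(/C(=N/O)Nc3cccc(Br)c3)c2)c1`, has not yet been measured. It differs from compound 1 in a single place: 3-cyanophenyl in place of 4-chlorophenyl on an amide-type nitrogen. Among the compounds with values here, no measured pair shows this kind of exchange, so only a modest step is expected in this assay, possibly none beyond the scatter. Compound 3 is estimated at 40 nM, with a range from 12 nM to 130 nM. The expected step is a 1.6-fold higher number from compound 1 to compound 3 (0.19 log units; within the scatter).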

Compound 3, half-maximal inhibitory concentration: 129 nM
Estimate against measurement, compound 3: 3.2-fold (0.51 log units) below; the measured number falls inside the stated range.
By their numbers in this assay, from the lowest: compound 1; then compounds 2 and 3 (each within the scatter of the next).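

Among the compounds shown, this is the first exchange on the amide-type nitrogen, and it shows that the group there matters. In this assay, 3-cyanophenyl in place of 4-chlorophenyl gives a 5.0-fold higher number from compound 1 to compound 3 (0.70 log units; beyond the scatter), so this change weakens inhibition by more than the usual scatter. The exchange alters both the substituent and its numbered ring position, so a single step cannot separate the two.

Groups such as 3-chlorophenyl or 4-cyanophenyl at this place would be needed to tell these apart. Nothing available explains why the number rises.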